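Extending the propyl chain to butyl on the core

This account rests on a few compounds, and the source may have more. Where it says the series, first, only, none or still open, it means among the compounds named here.

Compound 1 `Cc1cc2ccccc2nc1-c1cn(CCC(F)(F)C(F)(F)C(F)(F)C(F)(F)C(F)(F)C(F)(F)C(F)(F)C(F)(F)F)nn1` and compound 2 `CCCc1cc2ccccc2nc1-c1cn(CCC(F)(F)C(F)(F)C(F)(F)C(F)(F)C(F)(F)C(F)(F)C(F)(F)C(F)(F)F)nn1` share the same core and the same long fluorinated chain, and differ only in the small alkyl group on the core. In a functional assay on THP-1 cells (Homo sapiens) for cytotoxicity, read by MTT assay, with a stated time of 24 h (on this read-out lower numbers stand for stronger inhibition and higher numbers for weaker inhibition), compound 1 gives > 100 ug/mL, which is a limit of the assay and not a number. In this assay compound 2 gives > 100 ug/mL, likewise a limit. The step that the two limits leave unreadable from compound 1 to compound 2 cannot be read, since both values sit at the limit of > 100 ug/mL in this assay, at which 2 of the 2 values shown sit. Compound 3 `CCCCc1cc2ccccc2nc1-c1cn(CCC(F)(F)C(F)(F)C(F)(F)C(F)(F)C(F)(F)C(F)(F)C(F)(F)C(F)(F)F)nn1` has not been measured; it differs from compound 2 by methyl in place of hydrogen on a saturated chain carbon, three bonds along the chain from an aromatic carbon. For the measured compounds named here, the one measured step that bears on this change is unreadable, so no step beyond the scatter can be expected in either direction with any confidence. Compound 3 is expected to remain near the same limit, with an estimated step that the limit leaves unreadable from compound 2 to compound 3. For compound 3 the estimate in this assay is 150 ug/mL, with a range from 60 ug/mL to 400 ug/mL.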

Compound 3, half-maximal inhibitory concentration: > 100 ug/mL
Compound 3 ended at the assay's limit; the forecaster's own chance of this, stated with the estimate: 85%; the middle value lies beyond the limit too.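

No new step can be read among compound 1, compound 2 and compound 3, because all three values are limits of the assay and not numbers: the limit of > 100 ug/mL in this assay, at which 3 of the 3 values shown sit.

The compounds shown leave open whether the length of the alkyl group on the shared core makes any difference in this assay.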